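The source may hold more compounds than are shown below. What is called first, only, known or untested is meant among the compounds shown, and "the series" means these compounds.

Compound 1, `CC(=O)Nc1ccc(S(=O)(=O)NNc2ccc(Br)cc2)cc1`: 130 nM
Compound 2, `O=S(=O)(NNc1ccc(Br)cc1)c1ccc(Br)cc1`: 85 nM

Both were tested in an assay for inhibition of Indoleamine 2,3-dioxygenase 1 (Homo sapiens), read by spectrophotometry, with stated times of 1 h and 4 h; on this read-out lower numbers stand for stronger inhibition and higher numbers for weaker inhibition. Compound 2 gives the lower of the two numbers, but the gap between them is only a 1.5-fold lower number from compound 1 to compound 2 (0.18 log units; within the scatter), so the two cannot be told apart. Compound 3, `COC(=O)CCc1ccc(S(=O)(=O)NNc2ccc(Br)cc2)cc1`, has not yet been measured. It differs from compound 2 in one place: 2-(methoxycarbonyl)ethyl in place of bromo on an aromatic carbon. Among the measured compounds shown here, the one measured step at this same spot, from compound 1 to compound 2, exchanged acetamido for bromo and came to a 1.5-fold lower number from compound 1 to compound 2 (0.18 log units; within the scatter); it shows that swapping one group there for another left the number essentially unchanged. Nothing measured tells how the 2-(methoxycarbonyl)ethyl chain will behave, and it is larger than either group seen so far. The expectation is therefore a step within the scatter, if any, a 1.8-fold higher number from compound 2 to compound 3 (0.25 log units; within the scatter), and compound 3 is estimated at 150 nM, within a range of 50 nM to 500 nM.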

Compound 3, half-maximal inhibitory concentration: 121 nM
Compound 3: middle estimate off by 1.2-fold (0.09 log units), on the high side; the measured number falls inside the stated range.
By their numbers in this assay, from the lowest: compounds 2, 3 and 1 (each within the scatter of the next).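

Until now this position had carried only bromo and acetamido, and neither group is large. The 2-(methoxycarbonyl)ethyl chain, with 6 heavy atoms against the 1 of bromo, gives a 1.4-fold higher number from compound 2 to compound 3 (0.15 log units; within the scatter) and, in place of acetamido, a 1.1-fold lower number from compound 1 to compound 3 (0.03 log units; within the scatter), so in this assay all three groups cannot be told apart, even with this much larger group on the aromatic carbon. Nothing available explains why a group of this size makes so little measurable difference here.

As far as these compounds go, whether the number would stay this close with a carboxylic acid, an amine or a longer chain at this position remains open. Also open, from the compounds shown here alone, is how much the bromo shared by all three compounds contributes, as a hydrogen or a chloro in its place would be needed to show it.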